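Swapping the Amide Aryl Group: Fluorophenyl to Methylfuran

A few compounds are considered here, and "the series" means these few. Any claim that something is new, unique, unknown or untested is made for them only; others in the source may bear on it.

Compounds 1, 2 and 3 share one core and differ only in the group on the amide carbonyl. In a functional assay on A549 cells (Homo sapiens) for inhibition, read by MTT assay, with a stated time of 48 h (a higher number here means a weaker inhibitor, a lower number a stronger inhibitor), compound 1 `O=C(CCCCc1ccccc1)Nc1ccc(N2CCN(c3ccc(OC[C@@H]4CO[C@@](Cn5cncn5)(c5ccc(Cl)cc5Cl)O4)cc3)CC2)cc1` gives 2610 nM, compound 2 `O=C(Nc1ccc(N2CCN(c3ccc(OC[C@@H]4CO[C@@](Cn5cncn5)(c5ccc(Cl)cc5Cl)O4)cc3)CC2)cc1)C(/C=C/Cl)C/C=C/C(F)(F)F` gives 3830 nM, and compound 3 `O=C(Nc1ccc(N2CCN(c3ccc(OC[C@@H]4CO[C@@](Cn5cncn5)(c5ccc(Cl)cc5Cl)O4)cc3)CC2)cc1)c1cccc(F)c1` gives 6640 nM. Compound 3 stands at the high end of these numbers: a 2.5-fold higher number from compound 1 to compound 3 (0.41 log units; beyond the scatter), while a 1.7-fold higher number from compound 2 to compound 3 (0.24 log units; within the scatter). Compound 4 `Cc1ccc(C(=O)Nc2ccc(N3CCN(c4ccc(OC[C@@H]5CO[C@@](Cn6cncn6)(c6ccc(Cl)cc6Cl)O5)cc4)CC3)cc2)o1` carries the change (5-methylfuran-2-yl in place of 3-fluorophenyl on a carbonyl carbon). Among the measured compounds shown here, the steps that bear on this sit at the same carbonyl: a 1.5-fold higher number from compound 1 to compound 2 (0.17 log units; within the scatter) and the two just given, all small. A similarly small move is therefore expected for compound 4, most likely toward a somewhat lower number, estimated as a 1.3-fold lower number from compound 3 to compound 4 (0.12 log units; within the scatter). Compound 4 is expected to give about 5000 nM in this assay, within a range from 2300 nM to 11000 nM.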

Compound 4, half-maximal inhibitory concentration: 4750 nM
Compound 4: the middle estimate sits 1.1-fold (0.02 log units) above what was measured; measured number inside the range.
By their numbers in this assay, from the lowest: compounds 1, 2, 4 and 3 (each within the scatter of the next, the first and the last beyond it).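

In this assay, putting 5-methylfuran-2-yl in place of 3-fluorophenyl on the carbonyl carbon gives a 1.4-fold lower number from compound 3 to compound 4 (0.15 log units; within the scatter) even though the ring changes in size and gains a hetero atom. Alongside a 1.2-fold higher number from compound 2 to compound 4 (0.09 log units; within the scatter) and a 1.8-fold higher number from compound 1 to compound 4 (0.26 log units; within the scatter) this places compound 4 within the scatter of all three earlier compounds, although compound 1 and compound 3 lie beyond the scatter of each other. So this position has yet to show a large step.

On these data alone, whether an amine or a carboxylic acid on this carbonyl carbon would move the number further remains open. No evidence is available on why these steps are so small.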